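Swapping a small pyrrole for a larger imidazolylphenyl on the hydrazone

A few compounds are considered here, and "the series" means these few. Any claim that something is new, unique, unknown or untested is made for them only; others in the source may bear on it.

Three nucleoside hydrazones have been measured in an assay on CHO-K1 cells for displacement of a labelled ligand from adenosine receptor A1 (Homo sapiens), read by scintillation counting, with a stated time of 60 min; a higher number here means a weaker inhibitor, a lower number a stronger inhibitor. Compound 3 `Nc1nc(N/N=C/c2ccc[nH]2)nc2c1ncn2[C@@H]1O[C@H](CO)[C@@H](O)[C@H]1O` gives 8 nM and stands lowest of the three numbers. Its nearest neighbour, compound 1 `Nc1nc(N/N=C/c2cncs2)nc2c1ncn2[C@@H]1O[C@H](CO)[C@@H](O)[C@H]1O`, gives 22 nM, and the single-point change from thiazolyl to pyrrolyl is recorded as a 2.8-fold lower number from compound 1 to compound 3 (0.44 log units; beyond the scatter). The furthest is compound 2 `Nc1nc(N/N=C/c2ccc(-c3ccccc3)cc2)nc2c1ncn2[C@@H]1O[C@H](CO)[C@@H](O)[C@H]1O`, which carries a biphenyl group and gives 7860 nM; set beside compound 3 this is a very large gap.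

Compound 4 `Nc1nc(N/N=C/c2ccc(-n3ccnc3)cc2)nc2c1ncn2[C@@H]1O[C@H](CO)[C@@H](O)[C@H]1O` differs from compound 3 by one replacement: 4-(1H-imidazol-1-yl)phenyl in place of 1H-pyrrol-2-yl on a carbon with a double bond to nitrogen. Among the measured compounds shown here, no measured step covers exactly this swap. For the measured compounds named here, the only measured step, from compound 1 to compound 3, is modest and concerns two small five-membered rings. The change into compound 4 instead adds a large two-ring group, which resembles what compound 2 shows with its value of 7860 nM. A large rise in the number is therefore expected, though perhaps not quite as far as compound 2, giving an expected 380-fold higher number from compound 3 to compound 4 (2.57 log units; beyond the scatter). Compound 4 is estimated at 3000 nM, within a range from 500 nM to 15000 nM.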

Compound 4, inhibition constant: > 10000 nM
Compound 4 gave a limit, no number; the forecaster's own chance of this, stated with the estimate: 10%; at least 3.3-fold (0.52 log units) between middle value and limit.
By their numbers in this assay, from the lowest: compound 3; then compound 1; then compound 2. At a limit, above all of these: compound 4.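

In this assay compound 4 gave only a limit (> 10000 nM) and not a number. Even so, on this carbon with a double bond to nitrogen, replacing 1H-pyrrol-2-yl with 4-(1H-imidazol-1-yl)phenyl costs a great deal (an at least 1200-fold higher number from compound 3 to compound 4 (3.09 log units; beyond the scatter)), and replacing 1,3-thiazol-5-yl costs nearly as much (an at least 450-fold higher number from compound 1 to compound 4 (2.65 log units; beyond the scatter)). Among the compounds shown here, until now the biphenyl of compound 2 was the only two-ring group in view, and exchanging its outer phenyl for 1H-imidazol-1-yl brings no recovery, though no order can be claimed between the two because the floor of this step lies within the scatter (an at least 1.2-fold higher number from compound 2 to compound 4 (0.10 log units; that floor lies within the scatter)).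

Going by these compounds, the true value of compound 4 remains unknown. Also open, on these data alone, is whether a single phenyl ring carrying only an amine or a carboxylic acid would keep the low numbers of the five-membered rings or follow the two-ring groups.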